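Cyano for methoxycarbonyl: a single-concentration check

The source may report more compounds than this note shows. Statements on the series, on what has been measured and on what is new or still open speak of the compounds shown alone.

Of the compounds shown here, three have been measured in an assay on cells for inhibition of protein arginine N-methyltransferase 1 (Homo sapiens), read by scintillation counting, with stated times of 15 min and 60 min, tested at 9 uM; on this read-out higher numbers stand for more inhibition at the one concentration tested (going by the name of the read-out) and lower numbers for less inhibition. Compound 1 `CNCCN(C)c1nnnn1Cc1cccc(OC(F)(F)F)c1` gives 12% and compound 2 `CNCCN(C)c1nnnn1Cc1ccc(OC)cc1` gives 0%. Compound 3 `CNCCN(C)Cc1ccc(-c2ccc(C(=O)OC)cc2)o1` gives 32%, the highest of the three numbers; its gap to compound 1 and its larger gap to compound 2 both lie beyond the scatter. No two of these compounds differ in one place only, so no single-point step is available, and any comparison with compound 3 crosses several changes at once.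

Compound 4 `CNCCN(C)Cc1ccc(-c2ccc(C#N)cc2)o1` is the next member. It differs from compound 3 as cyano in place of methoxycarbonyl on an aromatic carbon. With no measured step of this kind in the series, the size of the step in this assay is uncertain: no change beyond the scatter or a modest drop both seem plausible, and a rise cannot be excluded. The estimate for compound 4 in this assay is 25%, with an expected range from 5% to 50%. This expectation corresponds to an estimated step of a number 7 percentage points lower from compound 3 to compound 4 (within the scatter).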

Compound 4, a percentage reported as inhibition, at one concentration (the size of the read-out at that concentration, not a potency): 35%
Beside the measured number, compound 4's estimate is 10 percentage points below it; the range from low to high includes it.
By their numbers in this assay, from the lowest: compound 2; then compound 1; then compounds 3 and 4 (each within the scatter of the next).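

In this assay, the series now has its first step that changes one place only: a number 3 percentage points higher from compound 3 to compound 4 (within the scatter). On this aromatic carbon, para to a large group, cyano can therefore stand in place of methoxycarbonyl with no change in the read-out beyond the scatter, so the methoxycarbonyl group is not required for this level of inhibition. Nothing available gives a reason why the two groups read alike.

The compounds shown leave open whether this carbon needs a substituent at all, and how a plain hydrogen, a carboxylic acid, a primary amide or an aminomethyl group would read there. On these data alone, a single concentration also gives no potency, so whether compound 3 and compound 4 would separate in a full concentration series remains unknown.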